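A few compounds are considered here, and "the series" means these few. Any claim that something is new, unique, unknown or untested is made for them only; others in the source may bear on it.

Compound 1 `Fc1ccc(NC(=S)Nc2cccc(C(F)(F)F)c2)cc1` gives 31000 nM
Compound 2 `Fc1ccccc1NC(=S)Nc1cccc(C(F)(F)F)c1` gives 47000 nM
Compound 3 `FC(F)(F)c1cccc(NC(=S)Nc2ccccc2Br)c1` is still to be measured

In an ADME assay on MT4 cells (Homo sapiens) for cytotoxicity (a higher number here means that more compound is tolerated, a lower number that less compound is tolerated), compound 2 gives 47000 nM and compound 1 gives 31000 nM and these two values lie within the scatter of each other. Compound 3 departs from compound 2 by a single change (bromo in place of fluoro on an aromatic carbon) with bromo in place of fluoro on an aromatic carbon, ortho to a large group. Within the data shown here, the only measured step (a 1.5-fold higher number from compound 1 to compound 2 (0.18 log units; within the scatter)) puts 2-fluorophenyl in place of 4-fluorophenyl and stays within the scatter. Among the measured compounds shown here, no measured compound carries bromo, so the data give no direct size for this change. Starting from compound 2 at 47000 nM no step beyond the scatter is expected in this assay with a slight lean towards a lower number. The expected step is a 1.4-fold lower number from compound 2 to compound 3 (0.15 log units; within the scatter) as an estimate only. For compound 3 the estimated value is 33000 nM with an expected range from 14000 nM to 70000 nM for repeated measurements.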

Compound 3, half-maximal cytotoxic concentration: 36000 nM
The estimate for compound 3 lay 1.1-fold (0.04 log units) below the measured number; the range from low to high includes it.
By their numbers in this assay, from the lowest: compounds 1, 3 and 2 (each within the scatter of the next).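

In this assay, going from 2-fluorophenyl to 2-bromophenyl gives a 1.3-fold lower number from compound 2 to compound 3 (0.12 log units; within the scatter), so on an aromatic carbon ortho to a large group this exchange of one halogen for another leaves the read-out within the scatter. Replacing 4-fluorophenyl with 2-bromophenyl gives a 1.2-fold higher number from compound 1 to compound 3 (0.06 log units; within the scatter), so that change, in which the halogen differs as well as its place, also cannot be told from the scatter, and compound 1, compound 2 and compound 3 cannot be ranked. Nothing available explains why the number holds so steady across these compounds.

The compounds shown leave open whether an amine or a carboxylic acid in place of the halogen would move the number beyond the scatter. They also leave open what a 4-bromophenyl group would give, and what would follow if the trifluoromethyl group gave way to something else.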